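Selenocyanate chain truncation on a shared quinazoline-free core

The source may hold more compounds than are shown below. What is called first, only, known or untested is meant among the compounds shown, and "the series" means these compounds.

Measured so far:
compound 1, `COc1ccc(N(C)c2nc(C)nc3ccccc23)cc1OCCCCC[Se]C#N`, 5210 nM in a functional assay on HepG2 cells (Homo sapiens) for inhibition, read by MTT assay, with a stated time of 48 h; a lower number here means a stronger inhibitor, a higher number a weaker inhibitor
compound 2, `COc1ccc(N(C)c2nc(C)nc3ccccc23)cc1OCCCCCC[Se]C#N`, 4890 nM

Compound 2 holds the lowest of the two numbers, and its nearest neighbour is compound 1, whose step a 1.1-fold lower number from compound 1 to compound 2 (0.03 log units; within the scatter) lies within the scatter, so the two cannot be ordered. Compound 3, `COc1ccc(N(C)c2nc(C)nc3ccccc23)cc1C[Se]C#N`, is not yet measured. Its difference from compound 2 is a group of 4 heavy atoms (2 carbon, 1 nitrogen, 1 selenium; no ring) in place of a group of 10 heavy atoms (7 carbon, 1 nitrogen, 1 oxygen, 1 selenium; no ring), on an aromatic carbon. Among the measured compounds shown here, the only measured step, from compound 1 to compound 2, concerned lengthening the chain by one carbon and changed nothing beyond the scatter; it bears only loosely on the far larger removal of the whole oxygen-linked chain that produces compound 3. For the measured compounds named here, no measured pair shows what that removal does, so the direction of the step is open. Compound 3 is therefore expected to lie near the measured pair, with a wide range, at 6000 nM (range 2000 nM to 20000 nM), a step of a 1.2-fold higher number from compound 2 to compound 3 (0.09 log units; within the scatter) that is expected to be small.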

Compound 3, half-maximal inhibitory concentration: 1110 nM
The estimate for compound 3 lay 5.4-fold (0.73 log units) above the measured number; the measured number lies below the stated range.
By their numbers in this assay, from the lowest: compound 3; then compounds 2 and 1 (each within the scatter of the next).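

In this assay, placing the group of 4 heavy atoms on the aromatic carbon ortho to a methoxy group, in place of the oxygen-linked chain of 10 heavy atoms, gives a 4.4-fold lower number from compound 2 to compound 3 (0.64 log units; beyond the scatter), and replacing the oxygen-linked chain of compound 1 in the same way gives a 4.7-fold lower number from compound 1 to compound 3 (0.67 log units; beyond the scatter). This position therefore responds to removal of the whole oxygen-linked chain, whereas the one-carbon change, a 1.1-fold lower number from compound 1 to compound 2 (0.03 log units; within the scatter), did not separate the two chain lengths. No measured evidence accounts for this result.

Compound 3 loses the ring-bound oxygen and most of the chain in one change, so the compounds shown do not separate the two. As far as these compounds go, it also remains open whether a shorter oxygen-linked ethyl or propyl chain ending in selenocyanate would give a number closer to that of compound 3 or to those of the longer chains.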